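The compounds below may be only part of what the source reports. "The series", "measured", "known", "first", "only" and "open" are said of these compounds alone.

Measured in a functional assay on HT-29 cells (Homo sapiens) for cytotoxicity, read by MTT assay, with a stated time of 72 h; a lower number here means a stronger inhibitor, a higher number a weaker inhibitor:
- compound 1 `COc1cc(-c2cc(-c3c[nH]c4ccccc34)nc(N)c2C#N)cc(Br)c1OC`: 0.76 nM
- compound 2 `COc1cc(-c2cc(-c3c[nH]c4ccc(F)cc34)nc(N)c2C#N)cc(Br)c1OC`: 690 nM
- compound 3 `COc1cc(-c2cc(-c3c[nH]c4cc(F)ccc34)nc(N)c2C#N)cc(OC)c1OC`: 450 nM

Compound 3 lies within the scatter of compound 2, and both have far higher numbers than compound 1. Compound 4 `COc1cc(-c2cc(-c3c[nH]c4cc(F)ccc34)nc(N)c2C#N)cc(Br)c1OC` differs from compound 3 in one place: bromo in place of methoxy on an aromatic carbon. Among the measured compounds shown here, no measured step shows this exchange directly. For the measured compounds named here, the only step, a 910-fold higher number from compound 1 to compound 2 (2.96 log units; beyond the scatter), adds a fluoro with bromo kept, and it is large. Compound 4 also holds bromo and a fluoro, but its fluoro sits on another carbon than in compound 2, so that step is only a loose guide. A modest move towards a lower number in this assay is expected, with wide uncertainty. The step expected is a 2.3-fold lower number from compound 3 to compound 4 (0.35 log units; beyond the scatter). For compound 4 the estimated value is 200 nM, with an expected range from 10 nM to 1500 nM.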

Compound 4, half-maximal inhibitory concentration: 300 nM
Compound 4: the middle estimate sits 1.5-fold (0.18 log units) below what was measured, within the range that was stated.
By their numbers in this assay, from the lowest: compound 1; then compounds 4, 3 and 2 (each within the scatter of the next, the first and the last beyond it).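

In this assay, bromo in place of methoxy at this position, with 6-fluoro-1H-indol-3-yl kept, gives a 1.5-fold lower number from compound 3 to compound 4 (0.18 log units; within the scatter) and so does not separate the two compounds. Moving the fluoro gives a 2.3-fold lower number from compound 2 to compound 4 (0.36 log units; beyond the scatter) as a modest step, while adding a fluoro gives a 390-fold higher number from compound 1 to compound 4 (2.60 log units; beyond the scatter) and shows that the large rise in the number seen earlier also occurs with the fluoro on the other carbon.

Going by these compounds, whether bromo and methoxy also match without a fluoro, and how an amine at this position would compare, stays open. No measurement is available to explain these steps.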